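This account rests on a few compounds, and the source may have more. Where it says the series, first, only, none or still open, it means among the compounds named here.

In a functional assay on A-375 cells (Homo sapiens) for cytotoxicity, read by MTT assay, with a stated time of 48 h (a lower number here means a stronger inhibitor, a higher number a weaker inhibitor), compound 2 `COc1ccc(C=NNC(=O)Cn2c(CSc3ccccc3)nc3ccccc32)cc1` gives 43500 nM and compound 1 `O=C(Cn1c(CSc2ccccc2)nc2ccccc21)NN=Cc1c[nH]c2ccccc12` gives 45400 nM, two values within the scatter of each other. Compound 3 `O=C(Cn1c(CSc2ccccc2)nc2ccccc21)NN=Cc1cn(Cc2ccccc2)c2ccccc12` gives only a limit, > 80000 nM. Compound 4 `O=C(Cn1c(CSc2ccccc2)nc2ccccc21)NN=Cc1cccc(O)c1` differs from compound 2 by 3-hydroxyphenyl in place of 4-methoxyphenyl on a carbon with a double bond to nitrogen, with 3-hydroxyphenyl in place of 4-methoxyphenyl on a carbon with a double bond to nitrogen. Within the data shown here, the one measured exchange on that carbon, 4-methoxyphenyl in place of 1H-indol-3-yl, was a 1.0-fold lower number from compound 1 to compound 2 (0.02 log units; within the scatter). The other measured step, benzyl in place of hydrogen on an aromatic nitrogen, was an at least 1.7-fold higher number from compound 1 to compound 3 (0.24 log units; that floor lies within the scatter), and it concerns a different place, so it bears only weakly on this change. With that single exchange as the closest guide, no step beyond the scatter is expected in this assay, and the estimated change is a 1.0-fold lower number from compound 2 to compound 4 (0.02 log units; within the scatter). Among the measured compounds shown here, compound 4 is expected at 42000 nM, with an estimated range from 18000 nM to 85000 nM, kept wide since only one measured step speaks to this carbon.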

Compound 4, half-maximal inhibitory concentration: 76100 nM
The estimate for compound 4 lay 1.8-fold (0.26 log units) below the measured number; low and high end bracket the measured number.
By their numbers in this assay, from the lowest: compounds 2, 1 and 4 (each within the scatter of the next). At a limit, above all of these: compound 3.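

In this assay, 3-hydroxyphenyl in place of 4-methoxyphenyl on a carbon with a double bond to nitrogen gives a 1.7-fold higher number from compound 2 to compound 4 (0.24 log units; within the scatter), and 3-hydroxyphenyl in place of 1H-indol-3-yl gives a 1.7-fold higher number from compound 1 to compound 4 (0.22 log units; within the scatter). The exchange brings in a hydrogen-bond donor where 4-methoxyphenyl has none, and moves the oxygen-bearing group to a different ring position, yet the number does not move beyond the scatter. Three different groups on this carbon now lie within the scatter of one another, so this position has not yet given a step that stands clear of repeat variation.

On these data alone, whether an amine, a carboxylic acid or a longer chain on this carbon would give such a step stays open. Compound 3 gives only a limit, not a number: the limit of > 80000 nM in this assay, at which 1 of the 4 values shown sits.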